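The compounds below may be only part of what the source reports. "The series", "measured", "known", "first", "only" and "open" are said of these compounds alone.

The measured compounds, in an assay on isolated protein for inhibition of Rho-associated protein kinase 1 (Homo sapiens), tested at 30 uM; a higher number here means more inhibition at the concentration tested (going by the name of the read-out), a lower number less inhibition:
compound 1, `c1ccc(Sc2ncnc3[nH]cnc23)cc1`, gives 33%;
compound 2, `Cn1cnc2c(Sc3ccccc3)ncnc21`, gives 6%;
compound 3, `c1ccc(CSc2ncnc3[nH]cnc23)cc1`, gives 28%.

Compound 2 differs from compound 1 by methyl in place of hydrogen on an aromatic nitrogen, and that change made a number 27 percentage points lower from compound 1 to compound 2 (beyond the scatter). Compound 3 and compound 1 differ in their cores, a difference that is not broken down here; their values in this assay lie within the scatter of each other. Among the measured compounds shown here, compound 4, `Cn1cnc2c(SCc3ccccc3)ncnc21`, not yet measured, differs from compound 3 by methyl in place of hydrogen on an aromatic nitrogen, the same change as the one from compound 1 to compound 2, at the same kind of place. Because the earlier change made a number 27 percentage points lower from compound 1 to compound 2 (beyond the scatter), a step of similar size is expected for compound 4, namely a number 23 percentage points lower from compound 3 to compound 4 (beyond the scatter). Compound 4 is therefore estimated at 5%, with a range from -5% to 20%.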

Compound 4, a percentage reported as inhibition, at one concentration (the size of the read-out at that concentration, not a potency): 1%
Estimate against measurement, compound 4: 4 percentage points above; measured number inside the range.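

In this assay, methyl in place of hydrogen on an aromatic nitrogen gave a number 27 percentage points lower from compound 3 to compound 4 (beyond the scatter). Set beside the earlier step, the change carried from one core to the other with no difference in size: the same change on two cores in this assay, a number 27 percentage points lower (beyond the scatter) from compound 1 to compound 2 and a number 27 percentage points lower (beyond the scatter) from compound 3 to compound 4, 0 percentage points apart, within the scatter of two such steps. Among the compounds shown here, this rests on only two pairs of compounds at a single tested concentration, so it shows nothing about other cores and gives no reason for the loss of inhibition.

The compounds shown leave open whether ethyl or a longer chain on that nitrogen would behave as methyl does. They also leave open what an amine or a carboxylic acid elsewhere on these molecules would do.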